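Phenethyl in Place of Phenoxy on a Thiourea Carbonyl

A few compounds are considered here, and "the series" means these few. Any claim that something is new, unique, unknown or untested is made for them only; others in the source may bear on it.

Of the compounds shown here, three built on a shared thiourea-bearing core have been tested in an ADME assay on Huh-7 cells (Homo sapiens) for cytotoxicity; a higher number here means that more compound is tolerated, a lower number that less compound is tolerated. Compound 1 `NC(=S)N1CCCc2c(OCCCCCOc3cccc4ccccc34)cccc21` gives only a limit of the assay, > 50000 nM. Compound 2 `O=C(NC(=S)N1CCc2cc(OCc3ccccc3)ccc21)c1ccccc1` gives a number, 45200 nM. Compound 3 `O=C(NC(=S)N1CCc2c(OCCCCCOc3ccc(Cl)cc3)cccc21)Oc1ccccc1` likewise reaches only a limit of the assay, > 50000 nM. Within the data shown here, compound 3 therefore stands at the limit of > 50000 nM in this assay, at which 2 of the 3 values shown sit, and no single change between two measured compounds has been mapped, so there is no measured step to lean on.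

Compound 4 `O=C(CCc1ccccc1)NC(=S)N1CCc2c(OCCCCCOc3ccc(Cl)cc3)cccc21` differs from compound 3 in one place: phenethyl in place of phenoxy on a carbonyl carbon. The carbonyl and the amide-type nitrogen stay, and only the group hanging off the carbonyl carbon is exchanged. On the numbers at hand, the change from compound 3 to compound 4 is expected to be none beyond the scatter of this assay, since the shown values sit close together and two of them are limits. The expected step of a number no higher from compound 3 to compound 4 (the limit leaves the size open) is accordingly near flat. Compound 4 is estimated at 50000 nM, with a range from 20000 nM to 100000 nM, and there is a fair chance that this assay again reports only a limit rather than a number.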

Compound 4, half-maximal cytotoxic concentration: > 50000 nM
Compound 4 was reported as a limit (the forecaster's own chance of this, stated with the estimate: 60%); the middle value lies on the limit itself.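

In this assay compound 4 gives > 50000 nM, which is only a limit of the assay. Compound 3 also gives only a limit, so no step can be read between compound 3 and compound 4. The compounds shown leave open how much of either compound the cells would tolerate, and most values stand at the same point: the limit of > 50000 nM in this assay, at which 3 of the 4 values shown sit.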